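Swapping a propyl amide for a fluorinated aryl amide

The compounds below may be only part of what the source reports. "The series", "measured", "known", "first", "only" and "open" are said of these compounds alone.

Compound 3 `CCCC(=O)Nc1ncc(-c2ccc(OC)cc2)n1C` shares its core with compound 1 `COc1ccc(-c2cnc(NC(=O)c3ccccc3OC)n2C)cc1` and compound 2 `COc1ccc(-c2cnc(NC(=O)c3cccc(Br)c3)n2C)cc1`, differing only in the group on the carbonyl carbon. In a toxicity assay on THP-1 cells (Homo sapiens) for inhibition (a lower number here means that less compound is tolerated, a higher number that more compound is tolerated), compound 3 reaches only a limit of the assay, > 100000 nM. Compound 1 likewise gives a limit, > 100000 nM. Compound 2 also stops at a limit, > 100000 nM. Compound 3 therefore stands level with both, all three sitting at the limit of > 100000 nM in this assay, at which 3 of the 3 values shown sit. Compound 4 `COc1ccc(-c2cnc(NC(=O)c3cccc(F)c3)n2C)cc1` differs from compound 3 by 3-fluorophenyl in place of propyl on a carbonyl carbon. The related measured steps, a step that the two limits leave unreadable from compound 1 to compound 3, a step that the two limits leave unreadable from compound 2 to compound 3 and a step that the two limits leave unreadable from compound 1 to compound 2, cannot be sized because every value sits at the limit of > 100000 nM in this assay, at which 3 of the 3 values shown sit. Compound 4 is therefore expected to remain at the limit, estimated at 150000 nM (from 50000 nM to 500000 nM). The expected step that the limit leaves unreadable from compound 3 to compound 4 is thus no more than scatter.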

Compound 4, half-maximal cytotoxic concentration: > 100000 nM
Compound 4 was reported as a limit; the forecaster's own chance of this, stated with the estimate: 85%; the middle value is on the limit's open side.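

No step from compound 1, compound 2 or compound 3 to compound 4 can be read, as all four stop at a limit: the limit of > 100000 nM in this assay, at which 4 of the 4 values shown sit.

As far as these compounds go, whether the groups on the carbonyl carbon differ at all in this assay stays open.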